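This account rests on a few compounds, and the source may have more. Where it says the series, first, only, none or still open, it means among the compounds named here.

Compounds measured in an assay on cell membranes from spleen (Cavia porcellus) for binding affinity to leukotriene B4 receptor 1 (Homo sapiens); on this read-out lower numbers stand for stronger inhibition and higher numbers for weaker inhibition:
- compound 1 `COC(=O)CCCCCOc1cc(-c2ccccc2)cc(-c2ccccc2)n1`: 40 nM
- compound 2 `O=C(O)CCCCCOc1cc(-c2ccccc2Cl)cc(-c2ccccc2)n1`: 200 nM
- compound 3 `O=C(O)CCCCOc1cc(-c2ccccc2)cc(-c2ccccc2)n1`: 50 nM

Compound 1 gives the lowest number of the three. Compound 3 sits closest, with a 1.3-fold higher number from compound 1 to compound 3 (0.10 log units; within the scatter), while compound 2 lies furthest away with a gap beyond the scatter. Compound 4 `O=C(O)CCCCCCOc1cc(-c2ccccc2)cc(-c2ccccc2)n1` has not yet been measured in this assay. It differs from compound 1 in one place: carboxymethyl in place of methoxycarbonyl on a saturated chain carbon, five bonds along the chain from an oxygen on an aromatic ring. The step from compound 1 to compound 3 is the only measured one that bears on this change, since it also exchanges the ester end of the chain for a free acid, and it stayed within the scatter. The same is therefore expected here, with a step of a 1.3-fold higher number from compound 1 to compound 4 (0.10 log units; within the scatter) that remains within the scatter. Compound 4 is estimated at 50 nM, in the range 20 nM to 130 nM.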

Compound 4, half-maximal inhibitory concentration: 25 nM
Estimate against measurement, compound 4: 2.0-fold (0.30 log units) above; the measured number falls inside the stated range.
By their numbers in this assay, from the lowest: compounds 4, 1 and 3 (each within the scatter of the next); then compound 2.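

Measured in this assay, carboxymethyl in place of methoxycarbonyl gives a 1.6-fold lower number from compound 1 to compound 4 (0.20 log units; within the scatter) and thus no clear separation between the ester and this free acid. Among the acids, 2-carboxyethyl in place of carboxy gives a 2.0-fold lower number from compound 3 to compound 4 (0.30 log units; within the scatter) and so adds a second change at this end of the chain that stays within the scatter. No evidence at hand accounts for this tolerance. Still open, from the compounds shown here alone, is whether a longer chain would hold the number in this range. The same goes for an amide in place of the carboxylic acid.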